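Swapping a pyrimidinyl ether for a trifluoromethylpyrimidinyl thioether

The source may report more compounds than this note shows. Statements on the series, on what has been measured and on what is new or still open speak of the compounds shown alone.

Compound 3 `CC(C)[C@H](NC(=O)COc1cccc2ccccc12)C(=O)N[C@@H](CC(=O)O)C(=O)COc1ccncn1` stands at the edge of what a functional assay on Jurkat cells (Homo sapiens) for inhibition (on this read-out lower numbers stand for stronger inhibition and higher numbers for weaker inhibition), can report: in this assay compound 3 gives > 200000 nM, which is a limit of the assay rather than a number. Compound 1 `CC(C)[C@H](NC(=O)COc1cccc2ccccc12)C(=O)N[C@@H](CC(=O)O)C(=O)CSc1nnnn1-c1ccccc1` gives 153000 nM in this assay. Compound 2 `CC(C)[C@H](NC(=O)COc1cccc2ccccc12)C(=O)N[C@@H](CC(=O)O)C(=O)CSc1nc2ccccc2s1` also returns a limit in this assay, > 200000 nM. Both limits sit at the same place, (the limit of > 200000 nM in this assay, at which 2 of the 3 values shown sit). Compound 4 `CC(C)[C@H](NC(=O)COc1cccc2ccccc12)C(=O)N[C@@H](CC(=O)O)C(=O)CSc1nccc(C(F)(F)F)n1` differs from compound 3 by (4-(trifluoromethyl)pyrimidin-2-yl)sulfanyl in place of (pyrimidin-4-yl)oxy on a saturated chain carbon bound to a carbonyl carbon. Among the measured compounds shown here, the only measured steps at this position are an at least 1.3-fold higher number from compound 1 to compound 3 (0.11 log units; that floor lies within the scatter) and a step that the two limits leave unreadable from compound 2 to compound 3, and both leave the size and direction open. Compound 4 is nonetheless expected to move back toward a readable number, an expected step of an at least 1.3-fold lower number from compound 3 to compound 4 (0.12 log units; that floor lies within the scatter). Compound 4 is therefore estimated at 150000 nM, with a range from 40000 nM to 500000 nM.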

Compound 4, half-maximal inhibitory concentration: > 200000 nM
Compound 4: no number, only a limit; the forecaster's own chance of this, stated with the estimate: 50%; middle value at least 1.3-fold (0.12 log units) away from the limit.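

Compound 4 also ends at a limit in this assay, so a pyrimidine carrying trifluoromethyl on the sulfur does not return a readable number at this position: the limit of > 200000 nM in this assay, at which 3 of the 4 values shown sit. The one step that can be read is an at least 1.3-fold higher number from compound 1 to compound 4 (0.11 log units; that floor lies within the scatter), which leaves compound 1 alone with a number among these sulfur-linked groups. The steps to compound 4 from compound 2 and compound 3 cannot be read, as both ends are limits.

From the compounds shown here alone, how far these limits lie from true values stays open, as does whether an amine in place of the trifluoromethyl would give a number.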